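The source may report more compounds than this note shows. Statements on the series, on what has been measured and on what is new or still open speak of the compounds shown alone.

Compound 1 `COc1ccc(N2CCN(CN3C(=O)/C(=N\NC(=S)NO)c4cc(F)ccc43)CC2)cc1` gives 260000 nM
Compound 2 `CONC(=S)N/N=C1\C(=O)N(CN2CCN(c3ccc(OC)cc3)CC2)c2ccc(C)cc21` gives 324000 nM
Compound 3 `CONC(=S)N/N=C1\C(=O)N(CN2CCN(c3ccccc3)CC2)c2ccc(F)cc21` gives 227000 nM

All three values come from an ADME assay on MT4 cells (Homo sapiens) for cytotoxicity, read by spectrophotometry, with a stated time of 5 days (a lower number here means that less compound is tolerated, a higher number that more compound is tolerated), and lie within the scatter of one another, so compound 3 (227000 nM) cannot be ranked against compound 1 or compound 2. Compound 4 `CONC(=S)N/N=C1\C(=O)N(CN2CCN(c3ccc(OC)cc3)CC2)c2ccc(F)cc21` differs from compound 3 by methoxy in place of hydrogen on an aromatic carbon, para to a large group, which turns phenyl into 4-methoxyphenyl (methoxy in place of hydrogen on an aromatic carbon). Among the measured compounds shown here, no measured pair isolates this change. With compound 1 (260000 nM) and compound 2 (324000 nM) so close to compound 3, no step beyond the scatter is expected in this assay. The estimated 1.1-fold higher number from compound 3 to compound 4 (0.06 log units; within the scatter) therefore stays within the scatter. For compound 4 the expected value is 260000 nM (estimated range 150000 nM to 420000 nM).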

Compound 4, half-maximal cytotoxic concentration: 276000 nM
The estimate for compound 4 lay 1.1-fold (0.03 log units) below the measured number, and the stated range covers the measured number.
By their numbers in this assay, from the lowest: compounds 3, 1, 4 and 2 (each within the scatter of the next).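

In this assay, methoxy in place of hydrogen on an aromatic carbon, para to a large group, gives a direct reading for phenyl to 4-methoxyphenyl (a 1.2-fold higher number from compound 3 to compound 4 (0.08 log units; within the scatter)). Two other single changes can now be read as well: fluoro in place of methyl on an aromatic carbon (a 1.2-fold lower number from compound 2 to compound 4 (0.07 log units; within the scatter)) and methyl in place of hydrogen on an oxygen (a 1.1-fold higher number from compound 1 to compound 4 (0.03 log units; within the scatter)), and all three stay within the scatter. No measurement offers an explanation for these steps.

As far as these compounds go, whether an amine, a carboxylic acid or a longer chain at the methoxy position would give a step beyond the scatter remains open. The same question stands for other groups at the fluoro and hydroxy-bearing places of the series.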